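Removing the Phenyl from a Bis-imidazoline: What to Expect

The source may report more compounds than this note shows. Statements on the series, on what has been measured and on what is new or still open speak of the compounds shown alone.

Compound 1 `c1ccc(N2CCN=C2c2ccc(C3=NCCN3c3ccccc3)cc2)cc1`: > 817000 nM
Compound 2 `c1cncc(N2CCN=C2c2ccc(C3=NCCN3c3cccnc3)cc2)c1`: > 813000 nM

In an ADME assay on MDCK cells (Canis lupus familiaris) for cytotoxicity, read by MTT assay, with a stated time of 24 h (on this read-out lower numbers stand for higher toxicity in this test and higher numbers for lower toxicity in this test), compound 1 gives > 817000 nM, which is a limit of the assay and not a measured number. Compound 2 gives > 813000 nM in this assay, likewise a limit. For the measured compounds named here, compound 1 therefore stands on a limit only, and the single other value shown is a limit as well, so no order between compound 1 and compound 2 can be read from these two entries; both simply sit at the top of what the assay reports, as the limit of > 817000 nM in this assay, at which 1 of the 2 values shown sits, and the limit of > 813000 nM in this assay, at which 1 of the 2 values shown sits, record. Going by the values given here, no step between two measured compounds exists in this set.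

Compound 3 `c1ccc(N2CCN=C2c2ccc(C3=NCCN3)cc2)cc1` differs from compound 1 by hydrogen in place of phenyl on an amine nitrogen in a ring. Among the compounds with values here, with no measured step to build on, the expectation for compound 3 rests on compound 1 resting at the limit of > 817000 nM in this assay, at which 1 of the 2 values shown sits. The step is expected to be none beyond the scatter, in no particular direction. Compound 3 is thus expected to give 800000 nM in this assay, within 250000 nM to 2500000 nM. The estimated step is an at least 1.0-fold lower number from compound 1 to compound 3 (0.00 log units; that floor lies within the scatter), most likely reported again only as a limit.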

Compound 3, half-maximal cytotoxic concentration: > 1030000 nM
Compound 3: only a limit was reported (the forecaster's own chance of this, stated with the estimate: 75%); middle value at least 1.2-fold (0.10 log units) away from the limit.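

In this assay compound 3 gives > 1030000 nM, which is a limit of the assay. For the compounds shown here, compound 1 also rests on a limit, and no step from compound 1 to compound 3 can be read. The compounds shown leave open whether hydrogen in place of phenyl on an amine nitrogen in a ring changes the read-out at all.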